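The source may hold more compounds than are shown below. What is called first, only, known or untested is meant among the compounds shown, and "the series" means these compounds.

Measured so far:
Compound 1 `Cc1cc(C)c(CN2CCc3c(F)cc(O[C@@H]4CCOC4)c(Cl)c3C2=O)c(=O)[nH]1` gives 260 nM in an assay on Sf9 cells for inhibition of histone-lysine N-methyltransferase EZH2 variant Y641N (Homo sapiens), read by scintillation counting, with a stated time of 60 min, in the presence of a further agent that is not named here; on this read-out higher numbers stand for weaker inhibition and lower numbers for stronger inhibition.
Compound 2 `Cc1cc(C)c(CN2CCc3ccc(-c4c(C)noc4C)c(Cl)c3C2=O)c(=O)[nH]1` gives 8.8 nM in this assay.
Compound 3 `Cc1cc(C)c(CN2CCc3c(Cl)cc(-c4cn[nH]c4C)c(Cl)c3C2=O)c(=O)[nH]1` gives 110 nM in this assay.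

On these numbers compound 3 stands second highest of the three: compound 1 sits at a higher number, and compound 2 sits far lower. Compound 4 `Cc1cc(C)c(CN2CCc3c(Cl)cc(-c4c(C)n[nH]c4C)c(Cl)c3C2=O)c(=O)[nH]1` is not yet measured. The difference from compound 3 to compound 4 is methyl in place of hydrogen on an aromatic carbon, so that a 5-methyl-1H-pyrazol-4-yl becomes a 3,5-dimethyl-1H-pyrazol-4-yl. Among the compounds with values here, no measured pair shows this change alone, and compound 2, though it carries a second methyl on its five-membered ring, differs in other places too. The expected step is small, a 1.6-fold lower number from compound 3 to compound 4 (0.20 log units; within the scatter), leaning toward stronger inhibition but hardly beyond the scatter. Compound 4 is therefore estimated at 70 nM, in the range 25 nM to 220 nM.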

Compound 4, half-maximal inhibitory concentration: 82 nM
The estimate for compound 4 lay 1.2-fold (0.07 log units) below the measured number, within the range that was stated.
By their numbers in this assay, from the lowest: compound 2; then compounds 4 and 3 (each within the scatter of the next); then compound 1.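

In this assay, within the data shown here, this pair gives the first direct reading of the change: swapping hydrogen for methyl on this ring carbon, next to the ring nitrogen, gives a 1.3-fold lower number from compound 3 to compound 4 (0.13 log units; within the scatter). A single added methyl at this position therefore has no effect that can be told apart from the scatter of repeated measurements. Nothing measured here explains why the step is so small.

As far as these compounds go, whether a longer chain such as ethyl, or an amine or a methoxy group, at this carbon would also leave the number unmoved remains open. So does whether removing the other methyl on this ring would matter.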